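The compounds below may be only part of what the source reports. "The series", "measured", "known", "first", "only" and "open" are said of these compounds alone.

Series notes on an assay on Jurkat E6.1 cells for inhibition of histone deacetylase 4 (Homo sapiens), read by fluorescence; a lower number here means a stronger inhibitor, a higher number a weaker inhibitor. Compound 1 `CCCN(CCC)C[C@@H](C)NC(=O)c1ccc(-c2noc(C(F)F)n2)cc1` gives 19000 nM in this assay. Compound 2 `CCCN(CCC)C[C@@H](C)NC(=O)c1ccc(-c2ncon2)cc1` gives > 50000 nM, which is a limit of the assay rather than a measured number. On the numbers shown compound 2 is the weaker of the two and sits at the limit of > 50000 nM in this assay, at which 1 of the 2 values shown sits, the step of an at least 2.6-fold higher number from compound 1 to compound 2 (0.42 log units; beyond the scatter) being the only one measured. The unmeasured compound 3 `CCCN(CCC)C[C@@H](C)NC(=O)c1ccc(-c2nc(C(F)(F)F)no2)cc1` differs from compound 2 by 3-(trifluoromethyl)-1,2,4-oxadiazol-5-yl in place of 1,2,4-oxadiazol-3-yl on an aromatic carbon. The step that bears on this change is the removal of difluoromethyl from compound 1 to compound 2, which raised the number beyond the scatter; placing a trifluoromethyl on the ring in compound 3 is the nearest reverse of that move, so a lower number is expected, about the size of that step. For compound 3 the expected step is an at least 2.5-fold lower number from compound 2 to compound 3 (0.39 log units; beyond the scatter). The estimate for compound 3 is 20000 nM, within 6000 nM to 60000 nM.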

Compound 3, half-maximal inhibitory concentration: > 50000 nM
Compound 3: a limit, no number (the forecaster's own chance of this, stated with the estimate: 30%); at least 2.5-fold (0.39 log units) between middle value and limit.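

In this assay compound 3 gives > 50000 nM, which is a limit of the assay and not a number. The change at this position, para to a large group, gives an at least 2.6-fold higher number from compound 1 to compound 3 (0.42 log units; beyond the scatter), while the step between compound 2 and compound 3 cannot be read, as both values are limits. A trifluoromethyl-bearing oxadiazole therefore does not by itself bring a measured number, and compound 1 remains the only compound shown with one: the limit of > 50000 nM in this assay, at which 2 of the 3 values shown sit.

Still open, as far as these compounds go, is whether the difference between compound 1 and compound 3 follows from trifluoromethyl in place of difluoromethyl or from the change of oxadiazole attachment, which a 5-(trifluoromethyl)-1,2,4-oxadiazol-3-yl group would separate. Also open, from the compounds shown here alone, is how a methyl or an amine on the same ring would read in this assay.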